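The source may report more compounds than this note shows. Statements on the series, on what has been measured and on what is new or still open speak of the compounds shown alone.

The compounds measured so far:

Compound 1, `COc1cccc(Oc2ccc3cc(NC(=O)c4ccc(OC)c(-c5cccc(OC)c5)c4)c(=O)oc3c2C)c1`, gives > 100000 nM in a functional assay on MCF7 cells (Homo sapiens) for antiproliferative activity (a higher number here means a weaker inhibitor, a lower number a stronger inhibitor), which is a limit of the assay and not a number.
Compound 2, `COc1ccc(Nc2ccc3cc(NC(=O)c4ccc(OC)c(-c5cccc(OC)c5)c4)c(=O)oc3c2C)cc1`, gives > 100000 nM in this assay, again a limit rather than a number.
Compound 3, `COc1cccc(-c2cc(C(=O)Nc3cc4ccc(Cc5ccccc5)c(C)c4oc3=O)ccc2OC)c1`, gives 7110 nM in this assay.

Among the compounds with values here, compound 3 therefore stands as the only compound with a number; the two other values sit at the limit of > 100000 nM in this assay, at which 2 of the 3 values shown sit. The step from compound 1 to compound 2, a step that the two limits leave unreadable from compound 1 to compound 2, cannot be read. Within the data shown here, the steps of an at least 14-fold lower number from compound 1 to compound 3 (1.14 log units; beyond the scatter) and an at least 14-fold lower number from compound 2 to compound 3 (1.14 log units; beyond the scatter) both show that the benzyl group goes with the only measurable value.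

Compound 4, `COc1ccc(Cc2ccc3cc(NC(=O)c4ccc(OC)c(-c5cccc(OC)c5)c4)c(=O)oc3c2C)cc1`, is not yet measured. It differs from compound 3 by methoxy in place of hydrogen on an aromatic carbon, so benzyl becomes 4-methoxybenzyl. Among the measured compounds shown here, no measured step concerns a methoxy added to the benzyl group; the measured steps exchange the benzyl group itself. The expectation for compound 4 in this assay is thus a step of a 1.2-fold lower number from compound 3 to compound 4 (0.07 log units; within the scatter), not beyond the scatter. Compound 4 is expected to give about 6000 nM, between 2500 nM and 16000 nM.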

Compound 4, half-maximal inhibitory concentration: > 100000 nM
Compound 4 was reported as a limit; the forecaster's own chance of this, stated with the estimate: 5%; middle value at least 16-fold (1.22 log units) away from the limit.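

In this assay, within the data shown here, the earlier steps exchanged the whole group on the core, whereas this one keeps the benzyl group and only turns its phenyl into 4-methoxyphenyl, giving an at least 14-fold higher number from compound 3 to compound 4 (1.14 log units; beyond the scatter). A number at this position therefore does not come with the benzyl group as such, since compound 4 carries that link and still gives no number, and among the compounds shown only the unsubstituted benzyl of compound 3 gives one. The value of compound 4 is a limit of the assay and not a number, so its steps from compound 1 and compound 2 cannot be read, and all three compounds with a methoxy on this outer ring stand together: the limit of > 100000 nM in this assay, at which 3 of the 4 values shown sit.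

The compounds shown leave open whether the methoxy is special or whether a fluorine, a methyl or a hydroxyl on the same ring would give the same result. They also do not say how a methoxy elsewhere on that ring would read.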